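The source may report more compounds than this note shows. Statements on the series, on what has been measured and on what is new or still open speak of the compounds shown alone.

Measured compounds:
compound 1, `CCC(C)(C)Cc1c[nH]c(CCc2ccc(-c3ccncc3)cc2)n1` — 101 nM
compound 2, `CCC(C)(C)Cc1c[nH]c(CCc2ccc(-c3cnccn3)cc2)n1` — 51 nM

Both were tested in an in vitro assay on CHO cells for displacement of a labelled ligand from Bombesin receptor subtype-3 (Homo sapiens), read by scintillation counting, with a stated time of 2 h; a lower number here means a stronger inhibitor, a higher number a weaker inhibitor. Within the data shown here, compound 2 stands with compound 1 as the only pair on record, and the two numbers lie within the scatter of each other, so neither can be set apart. Among the measured compounds shown here, the single step on record, a 2.0-fold lower number from compound 1 to compound 2 (0.30 log units; within the scatter), is the only one that touches the aryl group at this position, and it is itself within the scatter.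

Compound 3, `CCC(C)(C)Cc1c[nH]c(CCc2ccc(-c3ccc(F)cn3)cc2)n1`, is not yet measured. Its change from compound 2 is 5-fluoropyridin-2-yl in place of pyrazin-2-yl on an aromatic carbon. One ring with a single ring nitrogen now carries a fluorine in place of a ring with two nitrogens. For the measured compounds named here, the only comparable step was small, so the expected move in this assay is none beyond the scatter, with a 1.2-fold higher number from compound 2 to compound 3 (0.07 log units; within the scatter) as the expected step. Compound 3 is therefore estimated at about 60 nM, with a range of 25 nM to 150 nM.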

Compound 3, half-maximal inhibitory concentration: 19 nM
Beside the measured number, compound 3's estimate is 3.2-fold (0.50 log units) above it; the measured number lies below the stated range.
By their numbers in this assay, from the lowest: compound 3; then compounds 2 and 1 (each within the scatter of the next).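

In this assay the aryl group on the aromatic ring of carbon only, para to a large group, now moves the number beyond the scatter, with a 2.7-fold lower number from compound 2 to compound 3 (0.43 log units; beyond the scatter) when 5-fluoropyridin-2-yl replaces pyrazin-2-yl, whereas the earlier step at this place stayed within it. Set against pyridin-4-yl, the same group gives a 5.3-fold lower number from compound 1 to compound 3 (0.73 log units; beyond the scatter), so compound 3 stands apart from both earlier compounds, though both steps are modest. Nothing available gives a reason for this difference.

Going by these compounds, compound 3 differs from compound 2 both in its ring nitrogens and in carrying a fluorine, so the share of each in the step stays open. A pyridin-2-yl group without the fluorine, or one carrying chlorine or a nitrile instead, would be needed to separate them.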